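A few compounds are considered here, and "the series" means these few. Any claim that something is new, unique, unknown or untested is made for them only; others in the source may bear on it.

Measured compounds and their numbers:
compound 1, `O=C(Nc1cccc(-c2oc3cc(-c4ccc(F)cc4)ccc3c(=O)c2O)c1)c1ccccc1F`, 7240 nM;
compound 2, `COc1ccc(C(=O)Nc2cccc(-c3oc4cc(-c5ccc(F)cc5)ccc4c(=O)c3O)c2)cc1`, 16500 nM;
compound 3, `CCc1ccc(C(=O)Nc2cccc(-c3oc4cc(-c5ccc(F)cc5)ccc4c(=O)c3O)c2)cc1`, 9070 nM.

All three share one core and differ only in the aromatic group attached to the carbonyl carbon of the amide. In a functional assay on MDA-MB-231 cells (Homo sapiens) for antiproliferative activity, read by CCK-8 assay, with a stated time of 72 h (on this read-out lower numbers stand for stronger inhibition and higher numbers for weaker inhibition), compound 3 stands second highest of the three numbers, but its distance to compound 1 and to compound 2 lies within the scatter, so no order among them can be claimed.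

Compound 4, `O=C(Nc1cccc(-c2oc3cc(-c4ccc(F)cc4)ccc3c(=O)c2O)c1)c1ccc(Cl)nc1`, has not yet been measured. Compared with compound 3 the change is 6-chloropyridin-3-yl in place of 4-ethylphenyl on a carbonyl carbon.

For the measured compounds named here, three measured steps bear on swapping the aromatic group at this carbonyl carbon. The step of a 2.3-fold higher number from compound 1 to compound 2 (0.36 log units; beyond the scatter) is the only one beyond the scatter; the steps of a 1.3-fold higher number from compound 1 to compound 3 (0.10 log units; within the scatter) and a 1.8-fold lower number from compound 2 to compound 3 (0.26 log units; within the scatter) stay within it. The group entering compound 4 has not been tried in this series, so the expectation rests on how little this position has moved so far.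

For compound 4 in this assay a number close to that of compound 3 is expected, with the step of a 1.0-fold lower number from compound 3 to compound 4 (0.00 log units; within the scatter) estimated to stay within the scatter. The estimate for compound 4 is 9000 nM, with a range from 4000 nM to 20000 nM.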

Compound 4, half-maximal inhibitory concentration: 1760 nM
Compound 4: the middle estimate sits 5.1-fold (0.71 log units) above what was measured; measured number outside the range, below it.
By their numbers in this assay, from the lowest: compound 4; then compounds 1, 3 and 2 (each within the scatter of the next, the first and the last beyond it).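

In this assay, for the compounds shown here, this carbonyl carbon turns out to allow larger changes than the earlier compounds suggested: 6-chloropyridin-3-yl gives a 5.2-fold lower number from compound 3 to compound 4 (0.71 log units; beyond the scatter) and a 9.4-fold lower number from compound 2 to compound 4 (0.97 log units; beyond the scatter) and also a 4.1-fold lower number from compound 1 to compound 4 (0.61 log units; beyond the scatter), all beyond the scatter. Among the groups shown, 6-chloropyridin-3-yl alone brings both a nitrogen into the aromatic ring and a chlorine, so these data cannot tell which of the two goes with the lower number, or whether both are needed. Nothing available here explains the step.

A plain pyridin-3-yl and a 4-chlorophenyl at this carbonyl carbon would pull the two features apart. Also open, going by these compounds, is how a pyridine ring carrying an amine or a methoxy group in place of the chlorine would read.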